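The source may hold more compounds than are shown below. What is called first, only, known or untested is meant among the compounds shown, and "the series" means these compounds.

Among the compounds with values here, compound 1 `CC(C)(C)c1cc(NC(=O)c2ccc(Cl)cc2Cl)ccc1O` is the only member of this set with a numeric read-out: in an assay on isolated protein for antagonist activity at Bile acid receptor (Homo sapiens), read by HTRF, with a stated time of 30 min (a lower number here means a stronger inhibitor, a higher number a weaker inhibitor), compound 1 gives 13600 nM. Compound 2 `CC(C)(C)c1cc(NC(=O)c2ccc(Cl)cc2Cl)cc(C(C)(C)C)c1O` reaches only the assay limit > 100000 nM in this assay. Compound 3 `Cc1cc(NC(=O)c2ccc(Cl)cc2Cl)ccc1O` likewise sits at the limit > 100000 nM in this assay. Compound 4 `COc1ccc(NC(=O)c2ccc(Cl)cc2Cl)cc1C(C)(C)C` differs from compound 1 by methyl in place of hydrogen on an oxygen on an aromatic ring. Within the data shown here, no measured step touches that oxygen; the two known steps alter carbons of the shared core, an at least 7.3-fold higher number from compound 1 to compound 2 (0.86 log units; beyond the scatter) and an at least 7.3-fold higher number from compound 1 to compound 3 (0.86 log units; beyond the scatter), both capped by the limit of > 100000 nM in this assay, at which 2 of the 3 values shown sit. Since both of those steps weakened binding, a weakening step a 2.9-fold higher number from compound 1 to compound 4 (0.47 log units; beyond the scatter) is expected for compound 4 as well, its size uncertain. Compound 4 is estimated at 40000 nM in this assay, within 10000 nM to 150000 nM, with a fair chance of only a limit being reported.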

Compound 4, half-maximal inhibitory concentration: > 100000 nM
Compound 4: a limit, no number (the forecaster's own chance of this, stated with the estimate: 40%); middle value at least 2.5-fold (0.39 log units) from the limit.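

Hydroxy to methoxy gives an at least 7.3-fold higher number from compound 1 to compound 4 (0.86 log units; beyond the scatter) in this assay, so the oxygen on the aromatic ring is now a position where a single change removes the numeric read-out. Changes at this oxygen and at the carbons of the shared core therefore all weaken binding in the compounds shown. The step gives only a lower bound on the loss, as compound 4 is a limit and not a number: the limit of > 100000 nM in this assay, at which 3 of the 4 values shown sit.

As far as these compounds go, it remains open whether an amine or a carboxylic acid in place of the hydroxy would keep a numeric read-out. From the compounds shown here alone, how far compound 4 lies beyond its limit also remains open.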